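A Smaller Linker Between the Two Halves

A few compounds are considered here, and "the series" means these few. Any claim that something is new, unique, unknown or untested is made for them only; others in the source may bear on it.

Of the compounds shown here, three have been measured in a functional assay on HL-60 cells (Homo sapiens) for antiproliferative activity, read by MTT assay, with a stated time of 48 h; on this read-out lower numbers stand for stronger inhibition and higher numbers for weaker inhibition. Compound 2 `CC(C)[C@H](NC(=O)c1ccc(C(=O)Nc2ccc3c(c2)C(C)(C)CCC3(C)C)cc1)C(=O)OCc1c(-c2ccccc2)no[n+]1[O-]` gives 5850 nM, the lowest of the three numbers. Compound 1 `CC1(C)CCC(C)(C)c2cc(NC(=O)c3ccc(C(=O)OCCCCCOC(=O)c4ccc(OCc5c(-c6ccccc6)no[n+]5[O-])cc4)cc3)ccc21` gives 282000 nM, and compound 3 `CC1(C)CCC(C)(C)c2cc(NC(=O)c3ccc(C(=O)OCCOC(=O)c4ccc(OCc5c(-c6ccccc6)no[n+]5[O-])cc4)cc3)ccc21` gives 395000 nM; both lie far beyond the scatter from compound 2, which is therefore the strongest of the three here. Compound 4 `CC1(C)CCC(C)(C)c2cc(NC(=O)c3ccc(C(=O)NCC(=O)OCc4c(-c5ccccc5)no[n+]4[O-])cc3)ccc21` has not yet been measured. It differs from compound 2 in one place: hydrogen in place of isopropyl on a saturated chain carbon bound to an amide-type nitrogen and a carbonyl carbon. Within the data shown here, no measured pair isolates such a change, so the direction is uncertain; a modest weakening is expected, the step of a 2.1-fold higher number from compound 2 to compound 4 (0.31 log units; beyond the scatter). Compound 4 is estimated at 12000 nM, between 3000 nM and 50000 nM.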

Compound 4, half-maximal inhibitory concentration: 160 nM
Compound 4: middle estimate off by 75-fold (1.88 log units), on the high side, and the stated range ends above it.
By their numbers in this assay, from the lowest: compound 4; then compound 2; then compounds 1 and 3 (each within the scatter of the next).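

Measured by this assay the change to hydrogen in place of isopropyl gives a 37-fold lower number from compound 2 to compound 4 (1.56 log units; beyond the scatter) and counts as a large step. This saturated chain carbon is therefore a position where one change strongly shifts the number, and the isopropyl group is not needed for activity in this series. Nothing available explains the size of this shift.

Only hydrogen and isopropyl are shown on this carbon, so it remains open whether a methyl group would give a number closer to compound 4 or to compound 2. Going by these compounds, how an amine or a carboxylic acid on the same carbon would behave also remains open.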